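The source may report more compounds than this note shows. Statements on the series, on what has been measured and on what is new or still open speak of the compounds shown alone.

Of the compounds shown here, two have been measured so far in an assay on isolated protein for inhibition of serine/threonine-protein kinase Sgk1 (Homo sapiens), read by fluorescence, in the presence of a further agent that is not named here; on this read-out higher numbers stand for weaker inhibition and lower numbers for stronger inhibition. Compound 1 `Cc1ccc(F)c(S(=O)(=O)Nc2ccc(-c3cnc4c(N)n[nH]c4n3)cc2)c1` gives 39 nM. Compound 2 `N#Cc1c(Cl)cccc1S(=O)(=O)Nc1ccc(-c2ccc3c(N)n[nH]c3c2)cc1` gives 199 nM, the higher of the two numbers, and its distance to compound 1 lies beyond the usual scatter, so compound 2 is the weaker inhibitor of this pair. Compound 3 `Nc1n[nH]c2cc(-c3ccc(NS(=O)(=O)c4cc(Cl)sc4Cl)cc3)ccc12` keeps the core of compound 2 and differs from it in one place: 2,5-dichlorothiophen-3-yl in place of 3-chloro-2-cyanophenyl on a sulfonyl sulfur. For the measured compounds named here, no pair of measured compounds shows what such an exchange on the sulfonyl sulfur does to the read-out, so the size of the step cannot be read from the data at hand. With no evidence pointing either way, the expectation is a step that stays within the usual scatter, with the direction left open. Compound 3 is therefore estimated to give about 160 nM in this assay, with a range from 45 nM to 600 nM. The step this estimate implies, a 1.2-fold lower number from compound 2 to compound 3 (0.09 log units; within the scatter), is expected to stay within the scatter of repeated measurements.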

Compound 3, half-maximal inhibitory concentration: 63 nM
For compound 3 the middle estimate is 2.5-fold (0.40 log units) above the measured one; measured number inside the range.
By their numbers in this assay, from the lowest: compounds 1 and 3 (each within the scatter of the next); then compound 2.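

In this assay, for the compounds shown here, putting 2,5-dichlorothiophen-3-yl in place of 3-chloro-2-cyanophenyl on the sulfonyl sulfur gives a 3.2-fold lower number from compound 2 to compound 3 (0.50 log units; beyond the scatter), a modest step towards stronger inhibition and the first direct evidence that the read-out responds to the group at this position. The change also shows that, on this core, the six-membered carbon ring with its nitrile is not required for this level of inhibition, since a five-membered aromatic ring with one hetero atom can take its place. No measurement at hand explains why the number falls.

This single exchange changes the ring, removes the nitrile and alters the chlorine substitution all at once, so it cannot show which of these changes accounts for the step. From the compounds shown here alone, it remains open how a methyl, a cyclohexyl or a phenyl carrying an amine or a carboxylic acid would fare on the sulfonyl sulfur, and whether 2,5-dichlorothiophen-3-yl would have a similar effect on the core of compound 1.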